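A few compounds are considered here, and "the series" means these few. Any claim that something is new, unique, unknown or untested is made for them only; others in the source may bear on it.

Measured so far in the series:

compound 1, `O=[N+]([O-])c1cc(C(F)(F)F)cc([N+](=O)[O-])c1Oc1ccc(Cl)cc1/C=N\OCc1ccccc1`: 1790 nM
compound 2, `O=[N+]([O-])c1cc(C(F)(F)F)cc([N+](=O)[O-])c1Oc1ccc(Cl)cc1/C=N\OCc1ccccc1F`: 1020 nM
compound 3, `O=[N+]([O-])c1cc(C(F)(F)F)cc([N+](=O)[O-])c1Oc1c(Br)cc(Br)cc1/C=N\OCc1ccccc1`: 1480 nM

All three numbers come from a functional assay on HepG2 cells (Homo sapiens) for antiproliferative activity, read by MTT assay, with a stated time of 48 h; on this read-out higher numbers stand for weaker inhibition and lower numbers for stronger inhibition. Within the set, compound 1 gives 1790 nM, compound 2 gives 1020 nM and compound 3 gives 1480 nM; every pairwise gap among them lies within the scatter of repeats, so no order is read into them.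

The one single-point change measured is fluoro in place of hydrogen on an aromatic carbon
It made a step of a 1.8-fold lower number from compound 1 to compound 2 (0.24 log units; within the scatter).

Compound 3 carries a different core from compound 1; the difference between the two cores is not broken down here.

Compound 4, `O=[N+]([O-])c1cc(C(F)(F)F)cc([N+](=O)[O-])c1Oc1c(Br)cc(Br)cc1/C=N\OCc1ccccc1F`, has not yet been measured in this assay. It differs from compound 3 by fluoro in place of hydrogen on an aromatic carbon
The place is described in the same words as for the change from compound 1 to compound 2, so this is the same change on the other core.

The step from compound 3 to compound 4 is expected to be a 1.6-fold lower number from compound 3 to compound 4 (0.19 log units; within the scatter), set beside a 1.8-fold lower number from compound 1 to compound 2 (0.24 log units; within the scatter), because the same change on the first core gave a 1.8-fold lower number from compound 1 to compound 2 (0.24 log units; within the scatter), a step that itself sits within the scatter.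

Compound 4 is estimated at 950 nM, with a range from 450 nM to 2000 nM.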

Compound 4, half-maximal inhibitory concentration: 1100 nM
The estimate for compound 4 lay 1.2-fold (0.06 log units) below the measured number, and the stated range covers the measured number.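

In this assay, benzyl to 2-fluorobenzyl gives a 1.3-fold lower number from compound 3 to compound 4 (0.13 log units; within the scatter). Set beside the earlier step, the change carries from one core to the other with no difference that can be told apart: the same change on two cores in this assay, a 1.8-fold lower number (0.24 log units; within the scatter) from compound 1 to compound 2 and a 1.3-fold lower number (0.13 log units; within the scatter) from compound 3 to compound 4, 1.3-fold (0.12 log units) apart, within the scatter of two such steps. Both steps lie within the scatter, so the pairs show only that fluoro in place of hydrogen reads alike on the two cores at this resolution; they do not show that this change strengthens inhibition on either core, and two pairs give no rule for the wider series.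

What the compounds shown leave open is how other replacements for the fluoro on the benzyl group would read, such as a methoxy, a nitrile or an amine, and whether any of them would give a step beyond the scatter on both cores. Also open, as far as these compounds go, is how the two cores would compare if the benzyloxy gave way to a longer chain or a group carrying a carboxylic acid.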